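Phenylsulfonyl for Phenylcarbamoyl on the Piperazine-like Nitrogen

The compounds below may be only part of what the source reports. "The series", "measured", "known", "first", "only" and "open" are said of these compounds alone.

Compound 1 `CCC(=O)CCCN1CCN(C(C)=O)C(c2ncc(-c3ccc4ccccc4c3)[nH]2)C1`: > 32000 nM
Compound 2 `CCC(=O)CCCN1CCN(C(=O)Nc2ccccc2)C(c2ncc(-c3ccc4ccccc4c3)[nH]2)C1`: > 25000 nM

In an ADME assay on HeLa cells (Homo sapiens) for cytotoxicity, with a stated time of 72 h (on this read-out higher numbers stand for lower toxicity in this test and lower numbers for higher toxicity in this test), compound 1 gives > 32000 nM, which is a limit of the test and not a number. In this assay compound 2 gives > 25000 nM, again a limit rather than a number. Compound 2 thus stands at the limit of > 25000 nM in this assay, at which 1 of the 2 values shown sits. Compound 1 stands at the limit of > 32000 nM in this assay, at which 1 of the 2 values shown sits. Going by the values given here, the one measured step, a step that the two limits leave unreadable from compound 1 to compound 2, therefore has no readable size or direction. Compound 3 `CCC(=O)CCCN1CCN(S(=O)(=O)c2ccccc2)C(c2ncc(-c3ccc4ccccc4c3)[nH]2)C1` carries the change (phenylsulfonyl in place of phenylcarbamoyl on an amine nitrogen in a ring). Among the compounds with values here, with the only known step unreadable, no change beyond the scatter can be expected in either direction; both measured compounds simply sit at the top of the test range. Compound 3 is expected to give 30000 nM, between 15000 nM and 60000 nM, most likely reported once more as a limit. That estimate means an expected step that the limit leaves unreadable from compound 2 to compound 3 that stays within the scatter.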

Compound 3, half-maximal cytotoxic concentration: > 25000 nM
Compound 3 gave a limit, no number; the forecaster's own chance of this, stated with the estimate: 80%; the middle value is on the limit's open side.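

No step can be read among compound 1, compound 2 and compound 3, because each gives a limit of the test and not a number: the limit of > 25000 nM in this assay, at which 2 of the 3 values shown sit.

Whether acetyl, phenylcarbamoyl or phenylsulfonyl on the ring nitrogen makes any difference in this assay stays open, since no actual value is shown for any of them.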